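This account rests on a few compounds, and the source may have more. Where it says the series, first, only, none or still open, it means among the compounds named here.

Measured so far:
compound 1 `Cc1c(C)c2c(c(C)c1O)CCC(C)(COc1ccc(/C=C3\SC(=O)N(C)C3=O)cc1)O2`, 147%
compound 2 `Cc1c(C)c2c(c(C)c1OC(=O)CCCCCCCNC(=O)OC(C)(C)C)CCC(C)(COc1ccc(/C=C3\SC(=O)NC3=O)cc1)O2`, 79.3%

In an ADME assay on cells (Hepatocyte, Homo sapiens) for cytotoxicity, read by MTT assay, with a stated time of 90 min, tested at 100 uM (on this read-out higher numbers stand for a weaker effect at the one concentration tested and lower numbers for a stronger effect), compound 1 gives 147%, the higher of the two numbers; compound 2 gives 79.3%, a number far enough below it to lie beyond the scatter. Compound 3 `Cc1c(C)c2c(c(C)c1OC(=O)CCCCCCCN)CCC(C)(COc1ccc(/C=C3\SC(=O)N(C)C3=O)cc1)O2` is the next compound to be measured. It differs from compound 1 by (7-aminoheptyl)carbonyl in place of hydrogen on an oxygen on an aromatic ring. Within the data shown here, no measured pair isolates this change, so its size is uncertain. A downward step in this assay, beyond the scatter, is expected from compound 1 to compound 3, because compound 2 gives 79.3%. The estimated step of a number 52 percentage points lower from compound 1 to compound 3 (beyond the scatter) leads to an expected 95% for compound 3, within 60% to 140%.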

Compound 3, a percentage reported as activity, at one concentration (the size of the read-out at that concentration, not a potency): 84.5%
Compound 3: the middle estimate sits 10.5 percentage points above what was measured; low and high end bracket the measured number.
By their numbers in this assay, from the lowest: compounds 2 and 3 (each within the scatter of the next); then compound 1.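

In this assay, (7-aminoheptyl)carbonyl in place of hydrogen on an oxygen on an aromatic ring gives a number 62.5 percentage points lower from compound 1 to compound 3 (beyond the scatter). Among these compounds, this is the first pair to isolate a change at this oxygen, and it shows that this single change moves the read-out towards a stronger effect at the one concentration tested. Nothing available explains the size of this step.

On these data alone, it remains open whether a shorter chain, a longer chain or a plain acetyl group on this oxygen would give a similar step. As far as these compounds go, it is also open whether a carboxylic acid at the chain end would do so in place of the amine.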